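An Ethyl Group Enters the Shared Core

The compounds below may be only part of what the source reports. "The series", "measured", "known", "first", "only" and "open" are said of these compounds alone.

Measured so far:
compound 1, `CCC1(C)CC(=O)N(CC(=O)N2CCN(c3ccccc3Cl)CC2)C1=O`: 100 mg/kg
compound 2, `Cc1ccccc1N1CCN(C(=O)CN2C(=O)CC(C)C2=O)CC1`: 300 mg/kg

In a functional assay on the whole organism (strain CD1) with Mus musculus as the target, in the maximal electroshock model, with a stated time of 0.5 h (a higher number here means that more compound is needed for the effect, a lower number that less compound is needed), compound 2 gives 300 mg/kg, the highest of the two numbers, while compound 1 gives 100 mg/kg, a gap beyond the usual scatter. Compound 3, `CCC1(C)CC(=O)N(CC(=O)N2CCN(c3ccccc3C)CC2)C1=O`, has not yet been measured. It differs from compound 2 by ethyl in place of hydrogen on a saturated ring carbon. Among the measured compounds shown here, no pair of measured compounds isolates this change, so the expectation rests on compound 1, which gives 100 mg/kg. Compound 3 is expected to need a lower dose, a step of a 2.0-fold lower number from compound 2 to compound 3 (0.30 log units; within the scatter). For compound 3 the estimate is 150 mg/kg, within a range from 50 mg/kg to 300 mg/kg.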

Compound 3, minimum effective dose: 100 mg/kg
The estimate for compound 3 lay 1.5-fold (0.18 log units) above the measured number, within the range that was stated.
By their numbers in this assay, from the lowest: compounds 1 and 3 (each within the scatter of the next); then compound 2.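

In this assay, among the compounds shown here, the change of ethyl in place of hydrogen on a saturated ring carbon gives a 3.0-fold lower number from compound 2 to compound 3 (0.48 log units; beyond the scatter) as the first direct reading of this change. Methyl in place of chloro on an aromatic carbon gives no change at the digits printed from compound 1 to compound 3 (within the scatter) with the ethyl group present in both compounds. No measurement here offers an explanation for either step. The compounds shown leave open whether a propyl group or a phenyl ring on that ring carbon would lower the number further. They also leave open whether ethyl gives a similar step when chloro sits on the aromatic carbon.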